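A few compounds are considered here, and "the series" means these few. Any claim that something is new, unique, unknown or untested is made for them only; others in the source may bear on it.

In a functional assay on MDA-MB-231 cells (Homo sapiens) for cytotoxicity, read by MTT assay, with a stated time of 72 h (a higher number here means a weaker inhibitor, a lower number a stronger inhibitor), compound 1 (`COc1ccc(NC(=O)CN2CCN(c3nnc(Cc4ccncc4)c4ccccc34)CC2)cc1OC`) gives 100 nM, compound 2 (`O=C(CN1CCN(c2nnc(Cc3ccccc3)c3ccccc23)CC1)Nc1c(F)cccc1F`) gives 5490 nM, and compound 3 (`O=C(CN1CCN(c2nnc(Cc3ccccc3)c3ccccc23)CC1)Nc1ccc(F)c(F)c1`) gives 2750 nM. Compound 3 therefore stands within the usual scatter of compound 2. Its number is far from that of compound 1, but compound 1 differs from it in more than one place, so that gap says little about a single group.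

Compound 4 (`O=C(CN1CCN(c2nnc(Cc3ccccc3)c3ccccc23)CC1)Nc1cc(C(F)(F)F)ccc1Cl`) has not yet been measured. It keeps the shared core of compound 3 and changes only the group on the amide-type nitrogen: 2-chloro-5-(trifluoromethyl)phenyl in place of 3,4-difluorophenyl on an amide-type nitrogen. In words, 2-chloro-5-(trifluoromethyl)phenyl takes the place of 3,4-difluorophenyl.

Among the compounds with values here, only one measured step bears on this nitrogen: a 2.0-fold lower number from compound 2 to compound 3 (0.30 log units; within the scatter), where 3,4-difluorophenyl replaced 2,6-difluorophenyl. That step stayed small, so a large move is not expected here. Within the data shown here, it is thin evidence, though, since no measured compound carries chlorine or trifluoromethyl, and the range must stay wide.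

The expected change is a 1.1-fold lower number from compound 3 to compound 4 (0.04 log units; within the scatter), which means no shift beyond the scatter in either direction. For compound 4 the estimated value is 2500 nM, with an expected range from 800 nM to 8000 nM.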

Compound 4, half-maximal inhibitory concentration: 19500 nM
For compound 4 the middle estimate is 7.8-fold (0.89 log units) below the measured one, outside the stated range (above it).
By their numbers in this assay, from the lowest: compound 1; then compounds 3 and 2 (each within the scatter of the next); then compound 4.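

In this assay the group on the amide-type nitrogen can move the result beyond the scatter: 2-chloro-5-(trifluoromethyl)phenyl in place of 3,4-difluorophenyl gives a 7.1-fold higher number from compound 3 to compound 4 (0.85 log units; beyond the scatter) and in place of 2,6-difluorophenyl gives a 3.6-fold higher number from compound 2 to compound 4 (0.55 log units; beyond the scatter) on the same shared core. The two difluorophenyl compounds, compound 2 and compound 3, lay within the scatter of each other, so this position had looked insensitive, whereas the new group gives a weaker inhibitor than either of them. Nothing available explains the rise or says whether it comes from the chlorine, the trifluoromethyl or the two together.

On these data alone, the chlorine and the trifluoromethyl enter together, so their separate contributions stay open, and a phenyl carrying only one of them would be needed to separate them. As far as these compounds go, it is also open whether this position tolerates quite different groups on the phenyl ring, such as an amine or a carboxylic acid, and whether the rise would carry over to the pyridine-bearing core of compound 1, which differs from compound 4 in more than one place.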